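A few compounds are considered here, and "the series" means these few. Any claim that something is new, unique, unknown or untested is made for them only; others in the source may bear on it.

In an assay on isolated protein for agonist activity at Free fatty acid receptor 1 (Homo sapiens) (on this read-out higher numbers stand for an effect only at larger amounts of compound and lower numbers for an effect already at smaller amounts), compound 1 `CC#CC(CC(=O)O)c1ccc(OCc2ccn3cc(-c4ccccc4)nc3c2)cc1` gives 1260 nM. Compound 2 `CC#CC(CC(=O)O)c1ccc(OCc2ccc3nc(-c4cccc(C)c4)cn3c2)cc1` gives 1050 nM in this assay, and the gap between the two lies within the usual scatter, so they stand together on this read-out. Compound 3 `CC#CC(CC(=O)O)c1ccc(OCc2ccn3cc(-c4cc(F)ccc4F)nc3c2)cc1` differs from compound 1 in one place: 2,5-difluorophenyl in place of phenyl on an aromatic carbon. Within the data shown here, no measured pair shows this change, so its size is open; the expectation is for a step no larger than a modest one, if any, in either direction. Compound 3 is therefore estimated at 900 nM in this assay, within 400 nM to 2500 nM, which would mean an expected step of a 1.4-fold lower number from compound 1 to compound 3 (0.15 log units; within the scatter).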

Compound 3, half-maximal effective concentration: 639 nM
Estimate against measurement, compound 3: 1.4-fold (0.15 log units) above; the measured number falls inside the stated range.
By their numbers in this assay, from the lowest: compounds 3, 2 and 1 (each within the scatter of the next).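

In this assay, among these compounds, the exchange of phenyl for 2,5-difluorophenyl on an aromatic carbon of the five-membered ring gives a 2.0-fold lower number from compound 1 to compound 3 (0.29 log units; within the scatter) and so offers the first comparison that differs in one place. It shows that this position carries the two added fluorine atoms with no step beyond the scatter. Nothing at hand bears on the reason for this result. Still open, going by these compounds, is whether either fluorine alone matters, and whether an amine or a methoxy group on this phenyl would give a step beyond the scatter.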